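Swapping the Aromatic Group While Keeping the Long Chain

The compounds below may be only part of what the source reports. "The series", "measured", "known", "first", "only" and "open" are said of these compounds alone.

In a functional assay on WM164 cells (Homo sapiens) for antiproliferative activity, read by sulforhodamine B assay, with a stated time of 48 h (a higher number here means a weaker inhibitor, a lower number a stronger inhibitor), compound 1 `CCCCCCCCNC(=O)[C@@H]1CSC(c2cc(OC)c(OC)c(OC)c2)N1` gives 19600 nM, compound 2 `CCCCCCCCCCCCNC(=O)[C@@H]1CSC(c2cc(OC)c(OC)c(OC)c2)N1` gives 2400 nM, and compound 3 `CCCCCCCCCCCCCCCCNC(=O)[C@@H]1CSC(c2cc(OC)c(OC)c(OC)c2)N1` gives 700 nM, the lowest of the three numbers. Compound 4 `CCCCCCCCCCCCCCCCNC(=O)[C@@H]1CSC(c2ccc(NC(C)=O)cc2)N1` keeps the chain of compound 3 and changes only the group on a saturated ring carbon: 4-acetamidophenyl in place of 3,4,5-trimethoxyphenyl on a saturated ring carbon. The measured steps of an 8.2-fold lower number from compound 1 to compound 2 (0.91 log units; beyond the scatter) and a 3.4-fold lower number from compound 2 to compound 3 (0.54 log units; beyond the scatter) are modest, and a 28-fold lower number from compound 1 to compound 3 (1.45 log units; beyond the scatter) is large, but all three alter the chain, so none measures this swap directly. With no measured guide to its direction, the expected step is small: a 1.4-fold higher number from compound 3 to compound 4 (0.15 log units; within the scatter). Compound 4 is estimated at 1000 nM, with an expected range of 300 nM to 3500 nM.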

Compound 4, half-maximal inhibitory concentration: 600 nM
For compound 4 the middle estimate is 1.7-fold (0.22 log units) above the measured one, and the stated range covers the measured number.
By their numbers in this assay, from the lowest: compounds 4 and 3 (each within the scatter of the next); then compound 2; then compound 1.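

Unlike the earlier steps, which all alter the chain, this one changes the aromatic group on the saturated ring carbon, and in this assay it gives a 1.2-fold lower number from compound 3 to compound 4 (0.07 log units; within the scatter), a step within the scatter. With the long chain held constant, 4-acetamidophenyl therefore performs on a par with 3,4,5-trimethoxyphenyl, although the two groups differ in their heavy atoms and hydrogen-bond donors. No measurement available here accounts for this match. Still open, as far as these compounds go, is whether the match holds with the shorter chains of compound 1 and compound 2. Also open, from the compounds shown here alone, is how a phenyl ring carrying an amine or a carboxylic acid would fare on this ring carbon.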